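Cytotoxicity notes: cyclopropyl to methoxymethyl

The source may hold more compounds than are shown below. What is called first, only, known or untested is meant among the compounds shown, and "the series" means these compounds.

Of the compounds shown here, two have so far been read in an ADME assay on H1-HeLa cells (Homo sapiens) for cytotoxicity, read by MTT assay, with a stated time of 3 days; a higher number here means that more compound is tolerated, a lower number that less compound is tolerated. Compound 1 `CNC(=O)c1cc(Oc2ccc3c(C)c(-c4noc(C(F)(F)F)n4)sc3c2)ccn1` gives > 100000 nM, which is a limit of the assay and not a number. Within the data shown here, compound 2 `CNC(=O)c1cc(Oc2ccc(-c3noc(C4CC4)n3)cc2)ccn1` gives 32300 nM, the only actual number available, so its standing cannot yet be judged against another measured value. Compound 1 and compound 2 also differ in more than one place, and no single-change comparison exists in this assay.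

Compound 3 `CNC(=O)c1cc(Oc2ccc(-c3noc(COC)n3)cc2)ccn1` is the next to be read. The change is methoxymethyl in place of cyclopropyl on an aromatic carbon, so that 5-cyclopropyl-1,2,4-oxadiazol-3-yl becomes 5-(methoxymethyl)-1,2,4-oxadiazol-3-yl. Among the measured compounds shown here, the rest of the structure stays the same, and no measured step is available to size the change. A small move towards more compound tolerated is therefore expected, possibly no larger than the usual scatter. The expected step is a 1.4-fold higher number from compound 2 to compound 3 (0.14 log units; within the scatter). For compound 3 the estimated half-maximal cytotoxic concentration is 45000 nM, with an expected range from 18000 nM to 100000 nM.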

Compound 3, half-maximal cytotoxic concentration: 63400 nM
For compound 3 the middle estimate is 1.4-fold (0.15 log units) below the measured one; measured number inside the range.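

Among these compounds, this is the first single-change comparison in this assay, and it shows a 2.0-fold higher number from compound 2 to compound 3 (0.29 log units; within the scatter), so the exchange of methoxymethyl for cyclopropyl does not separate compound 2 from compound 3. On this aromatic carbon, next to the ring nitrogen and the ring oxygen, the three-membered carbon ring can therefore give way to an open group with 3 heavy atoms and 1 hydrogen-bond acceptor without a change that can be told from the usual scatter of repeated measurements. This single step sizes only one exchange, and any further rise from compound 3 can be followed only a short way before the assay reaches its limit: the limit of > 100000 nM in this assay, at which 1 of the 3 values shown sits.

Compound 1 differs from compound 2 in more than one place, so it gives no reading of trifluoromethyl at this position on its own, and the part played by the rest of its structure stays unresolved. As far as these compounds go, it also remains open how this assay would respond to an amine, a carboxylic acid or a longer ether chain on the 1,2,4-oxadiazol ring carbon that carries methoxymethyl in compound 3.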